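The source may hold more compounds than are shown below. What is called first, only, known or untested is meant among the compounds shown, and "the series" means these compounds.

Values in a functional assay on LNCaP cells (Homo sapiens) for antiproliferative activity, read by WST assay, with a stated time of 3 days (on this read-out lower numbers stand for stronger inhibition and higher numbers for weaker inhibition), are as follows
- Compound 1 `CCOc1c(-c2cc(OC)c(OC)c(OC)c2)oc2ccccc2c1=O` gives 5400 nM
- Compound 2 `CCCCCCCOc1c(-c2cc(OC)c(OC)c(OC)c2)oc2ccccc2c1=O` gives > 50000 nM as a limit of the assay, not a number
- Compound 3 `CCCC(C)Oc1c(-c2cc(OC)c(OC)c(OC)c2)oc2ccccc2c1=O` gives 15100 nM

Compound 3 holds the higher of the two actual numbers, and the gap is a 2.8-fold higher number from compound 1 to compound 3 (0.45 log units; beyond the scatter) (the nearest neighbour). Compound 4 `CCN(CC)CCCOc1c(-c2cc(OC)c(OC)c(OC)c2)oc2ccccc2c1=O` carries 3-(diethylamino)propyl in place of 1-methylbutyl on an oxygen on an aromatic ring. Within the data shown here, the steps that bear on this changed only carbon chains, namely a 2.8-fold higher number from compound 1 to compound 3 (0.45 log units; beyond the scatter) and an at least 9.2-fold higher number from compound 1 to compound 2 (0.96 log units; beyond the scatter) (both toward weaker inhibition). The new chain alone contains nitrogen, so these steps guide it only loosely. Compound 4 is expected to fall back toward compound 1 at 5400 nM and thus below compound 3. The expected step is a 2.5-fold lower number from compound 3 to compound 4 (0.40 log units; beyond the scatter) and remains uncertain. The estimate for compound 4 is 6000 nM (range 1500 nM to 25000 nM).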

Compound 4, half-maximal inhibitory concentration: 37600 nM
Compound 4: the middle estimate sits 6.3-fold (0.80 log units) below what was measured; measured number outside the range, above it.
By their numbers in this assay, from the lowest: compound 1; then compound 3; then compound 4. At a limit, above all of these: compound 2.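

In this assay the move from 1-methylbutyl to 3-(diethylamino)propyl on an oxygen on an aromatic ring gives a 2.5-fold higher number from compound 3 to compound 4 (0.40 log units; beyond the scatter) as its step, and a 7.0-fold higher number from compound 1 to compound 4 (0.84 log units; beyond the scatter) remains the gap to the short chain. Nitrogen in the chain therefore does not restore the activity lost with the longer carbon chains, since compound 4 is weaker than both compound 1 and compound 3. The step of an at least 1.3-fold lower number from compound 2 to compound 4 (0.12 log units; that floor lies within the scatter) gives only a floor, because compound 2 stands at a limit of the assay: the limit of > 50000 nM in this assay, at which 1 of the 4 values shown sits.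

Still open, from the compounds shown here alone, is whether a shorter amine chain, such as 2-(dimethylamino)ethyl, or a chain ending in a carboxylic acid would match or pass compound 1.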